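Replacing ethyl with methylsulfonyl in compound 2

This account rests on a few compounds, and the source may have more. Where it says the series, first, only, none or still open, it means among the compounds named here.

Measured so far in a functional assay on HeLa cells (Homo sapiens) for cytotoxicity; on this read-out lower numbers stand for stronger inhibition and higher numbers for weaker inhibition:
- compound 1 `Cc1ccc(S(=O)(=O)Oc2ccc3c(c2)C(=O)C=CC3=O)cc1` gives 15100 nM
- compound 2 `CCOc1ccc2c(c1)C(=O)C=CC2=O` gives 25100 nM

Compound 2 lies within the scatter of compound 1, so the two numbers set no order between them. Compound 3 `CS(=O)(=O)Oc1ccc2c(c1)C(=O)C=CC2=O` is still unmeasured. It carries methylsulfonyl in place of ethyl on an oxygen on an aromatic ring. For the measured compounds named here, no measured pair differs in one place, so the effect of this change in this assay has no direct precedent. Going by the values given here, the only guide is the narrow span from compound 1 (15100 nM) to compound 2 (25100 nM). The expected change is a 1.4-fold lower number from compound 2 to compound 3 (0.14 log units; within the scatter), a slightly lower number but nothing beyond the scatter. Compound 3 is estimated at 18000 nM, with an expected range from 7000 nM to 45000 nM.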

Compound 3, half-maximal inhibitory concentration: 17700 nM
Estimate against measurement, compound 3: 1.0-fold (0.01 log units) above, within the range that was stated.
By their numbers in this assay, from the lowest: compounds 1, 3 and 2 (each within the scatter of the next).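

In this assay, for the compounds shown here, the swap of methylsulfonyl for ethyl on the oxygen on the aromatic ring reads a 1.4-fold lower number from compound 2 to compound 3 (0.15 log units; within the scatter) and the swap of methyl for 4-methylphenyl on the sulfonyl sulfur reads a 1.2-fold higher number from compound 1 to compound 3 (0.07 log units; within the scatter) as the first single-place comparisons. With both steps within the scatter, ethyl, methylsulfonyl and the 4-methylphenyl sulfonyl group on this oxygen set no order among compound 1, compound 2 and compound 3, so neither the exchange at the oxygen nor the exchange at the sulfur separates these compounds. Nothing at hand speaks to why these steps are this small.

Still open, as far as these compounds go, is whether any group on this oxygen moves the number beyond the scatter, for example a free hydroxyl, a 2-aminoethyl chain, a carboxylic acid on a short chain or a longer chain such as butyl. Also open, from the compounds shown here alone, is how changes on the shared core itself would read against these three compounds.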